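A few compounds are considered here, and "the series" means these few. Any claim that something is new, unique, unknown or untested is made for them only; others in the source may bear on it.

In a toxicity assay on L02 cells (Homo sapiens) for cytotoxicity, read by MTT assay, with a stated time of 72 h (a lower number here means a stronger inhibitor, a higher number a weaker inhibitor), compound 1 (`O=C1c2c[n+]([O-])c3ccccc3c2C(=O)c2c1c1ccccc1n2Cc1cn([C@@H]2C[C@H](O)[C@@H](CO)O2)nn1`) gives 630 nM and compound 2 (`O=C1c2c[n+]([O-])c3ccccc3c2C(=O)c2c1c1ccccc1n2CCN1CCCC1`) gives 930 nM and these two values lie within the usual scatter of each other. Compound 3 (`CN(C)CCCCn1c2c(c3ccccc31)C(=O)c1c[n+]([O-])c3ccccc3c1C2=O`) differs from compound 2 by one change on a saturated chain carbon, two bonds along the chain from an aromatic nitrogen (2-(dimethylamino)ethyl in place of pyrrolidin-1-yl on a saturated chain carbon, two bonds along the chain from an aromatic nitrogen). Among the compounds with values here, no measured pair shows this change, so the expectation rests on compound 2 at 930 nM alone. The expected step of a 1.2-fold lower number from compound 2 to compound 3 (0.07 log units; within the scatter) stays within the scatter, with no direction favoured. Compound 3 is estimated at 800 nM (range 300 nM to 2200 nM).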

Compound 3, half-maximal inhibitory concentration: 300 nM
For compound 3 the middle estimate is 2.7-fold (0.43 log units) above the measured one; measured number inside the range.
By their numbers in this assay, from the lowest: compound 3; then compounds 1 and 2 (each within the scatter of the next).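

In this assay, replacing pyrrolidin-1-yl with 2-(dimethylamino)ethyl on a saturated chain carbon, two bonds along the chain from an aromatic nitrogen, gives a 3.1-fold lower number from compound 2 to compound 3 (0.49 log units; beyond the scatter), so the number at this position does respond to the change, if modestly. The exchange keeps the same heavy-atom count but removes the ring. Nothing measured here explains the step.
The compounds shown leave open whether the loss of the ring or the longer chain accounts for it, since 4-(dimethylamino)butyl differs from 2-(pyrrolidin-1-yl)ethyl in both. A 4-(pyrrolidin-1-yl)butyl chain would separate the two.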